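Pyridin-3-yl for phenyl on the carbonyl of compound 1

The source may hold more compounds than are shown below. What is called first, only, known or untested is meant among the compounds shown, and "the series" means these compounds.

In a functional assay on BXPC-3 cells (Homo sapiens) for antiproliferative activity, read by sulforhodamine B assay, with a stated time of 72 h (on this read-out higher numbers stand for weaker inhibition and lower numbers for stronger inhibition), compound 1 `CC(C)(C)c1[nH]cnc1/C=c1\[nH]c(=O)/c(=C/c2cccc(C(=O)c3ccccc3)c2)[nH]c1=O` gives 0.63 nM, the lower of the two numerical values in the series. Compound 2 `O=C(c1ccccc1)c1cccc(/C=c2\[nH]c(=O)/c(=C/c3ccccn3)[nH]c2=O)c1` gives 6.27 nM. That change, pyridin-2-yl in place of 5-(tert-butyl)-1H-imidazol-4-yl, is a 10-fold higher number from compound 1 to compound 2 (1.00 log units; beyond the scatter), and it lies at a different place from the one now in question. Compound 3 `O=C(c1cccc(/C=c2\[nH]c(=O)/c(=C/c3ccccn3)[nH]c2=O)c1)N1CCCCC1` is reported only as a limit, > 500 nM. Piperidin-1-yl in place of phenyl on a carbonyl carbon gives an at least 79-fold higher number from compound 2 to compound 3 (1.90 log units; beyond the scatter), the only measured step at that place.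

Compound 4 `CC(C)(C)c1[nH]cnc1/C=c1\[nH]c(=O)/c(=C/c2cccc(C(=O)c3cccnc3)c2)[nH]c1=O` carries pyridin-3-yl in place of phenyl on a carbonyl carbon, with pyridin-3-yl in place of phenyl on a carbonyl carbon. A six-membered aromatic ring stays there, now with one hetero atom, so a step well short of an at least 79-fold higher number from compound 2 to compound 3 (1.90 log units; beyond the scatter) is expected, towards higher numbers in this assay. The expected step is a 3.2-fold higher number from compound 1 to compound 4 (0.50 log units; beyond the scatter). The value estimated for compound 4 is 2 nM, with an expected range from 0.5 nM to 10 nM.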

Compound 4, half-maximal inhibitory concentration: 4.05 nM
Compound 4: middle estimate off by 2.0-fold (0.31 log units), on the low side, within the range that was stated.
By their numbers in this assay, from the lowest: compound 1; then compounds 4 and 2 (each within the scatter of the next). At a limit, above all of these: compound 3.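

For the compounds shown here, replacing phenyl with pyridin-3-yl on the carbonyl gives the first step at this place with a number at both ends in this assay: a 6.4-fold higher number from compound 1 to compound 4 (0.81 log units; beyond the scatter). The earlier step at this place ended at compound 3, which is reported only as a limit, > 500 nM. The new step is beyond the scatter, so the nitrogen in the ring costs activity, yet compound 4 still gives 4.05 nM, and nothing measured here accounts for the loss.

Still open, from the compounds shown here alone, is whether pyridin-2-yl or pyridin-4-yl on the carbonyl would give a step of similar size, and how a phenyl ring carrying an amine or a carboxylic acid would read. Also open, going by these compounds, is whether the same replacement gives a similar step with the pyridin-2-yl of compound 2 in place of the 5-(tert-butyl)-1H-imidazol-4-yl.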